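The compounds below may be only part of what the source reports. "The series", "measured", "known", "first", "only" and "open" are said of these compounds alone.

Working notes on the series. Among the compounds with values here, compound 2 `COc1ccc(F)cc1CNCCCNc1ccnc2cc(-c3ccc(C(F)(F)F)cc3)ccc12` gives 32000 nM in a physicochemical assay for solubility, with a stated time of 18 h, at pH 7.4 (on this read-out lower numbers stand for lower solubility and higher numbers for higher solubility), the highest of the two numbers so far. Compound 1 `COc1cccc(Oc2ccc3c(NCCCNCc4cccc(OC)c4O)ccnc3c2)c1` gives 14500 nM in this assay; its gap to compound 2 lies beyond the scatter, but the two differ at more than one place, so the pair is read only as two values. Compound 3 `COc1cccc(CNCCCNc2ccnc3cc(-c4ccc(C(F)(F)F)cc4)ccc23)c1O` is not yet measured in this assay. It differs from compound 2 by 2-hydroxy-3-methoxyphenyl in place of 5-fluoro-2-methoxyphenyl on a saturated chain carbon bound to an amine nitrogen. Compound 3 thus carries the same group as compound 1 on the saturated chain carbon bound to the amine nitrogen, set on the core of compound 2. Within the data shown here, no single-point step between measured compounds exists, so the size of the change in this assay cannot be taken from the data. The expected step for compound 3 is a 1.3-fold lower number from compound 2 to compound 3 (0.11 log units; within the scatter), which would stay within the scatter. Compound 3 is estimated at 25000 nM in this assay, with a range from 8000 nM to 70000 nM.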

Compound 3, solubility: 32000 nM
The estimate for compound 3 lay 1.3-fold (0.11 log units) below the measured number; the range from low to high includes it.
By their numbers in this assay, from the lowest: compound 1; then compounds 2 and 3 (each within the scatter of the next).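

In this assay, 2-hydroxy-3-methoxyphenyl in place of 5-fluoro-2-methoxyphenyl on a saturated chain carbon bound to an amine nitrogen gives no change at the digits printed from compound 2 to compound 3 (within the scatter) and so leaves the read-out within the scatter on the core of compound 2, even with a hydrogen-bond donor entering. Within the data shown here, with 2-hydroxy-3-methoxyphenyl held on the chain, 4-(trifluoromethyl)phenyl in place of 3-methoxyphenoxy on an aromatic carbon gives a 2.2-fold higher number from compound 1 to compound 3 (0.34 log units; beyond the scatter) as the first single-place step beyond the scatter, and a modest one. No measurement at hand offers an explanation for either step.

Going by these compounds, whether the step at the aromatic carbon keeps its size with 5-fluoro-2-methoxyphenyl on the chain stays open. Also open, on these data alone, is how the read-out responds to a carboxylic acid on that aromatic carbon or to a longer chain.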